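From hexylamino to diisobutylamino on a carbonyl carbon

The source may report more compounds than this note shows. Statements on the series, on what has been measured and on what is new or still open speak of the compounds shown alone.

Compound 1 `COc1ccc(/C=C/c2cc(OC)cc(OC)c2/C=C/C(=O)N2CCC(Cl)CC2)cc1` gives 4950 nM
Compound 2 `CCCCCCNC(=O)/C=C/c1c(/C=C/c2ccc(OC)cc2)cc(OC)cc1OC` gives 5530 nM

Among the measured compounds shown here, in a functional assay on MCF7 cells (Homo sapiens) for inhibition, read by MTT assay, with a stated time of 48 h (on this read-out lower numbers stand for stronger inhibition and higher numbers for weaker inhibition), compound 2 stands within the scatter of compound 1, the only other measured compound, with a 1.1-fold higher number from compound 1 to compound 2 (0.05 log units; within the scatter) as the step between them. Compound 3 `COc1ccc(/C=C/c2cc(OC)cc(OC)c2/C=C/C(=O)N(CC(C)C)CC(C)C)cc1` carries diisobutylamino in place of hexylamino on a carbonyl carbon, a difference counted as diisobutylamino in place of hexylamino on a carbonyl carbon from compound 2. For the measured compounds named here, the one measured step changed the group on that same carbonyl carbon. Going by the values given here, with a 1.1-fold higher number from compound 1 to compound 2 (0.05 log units; within the scatter) as the only guide, no step beyond the scatter is expected in this assay for compound 3. Among the compounds with values here, this is thin evidence, as no measured compound carries diisobutylamino. The estimate therefore means a 1.1-fold lower number from compound 2 to compound 3 (0.04 log units; within the scatter) as the expected step. Compound 3 is estimated at 5000 nM, with an expected range from 2000 nM to 12000 nM.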

Compound 3, half-maximal inhibitory concentration: 2390 nM
Beside the measured number, compound 3's estimate is 2.1-fold (0.32 log units) above it; the measured number falls inside the stated range.
By their numbers in this assay, from the lowest: compound 3; then compounds 1 and 2 (each within the scatter of the next).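

In this assay, among the compounds shown here, the group on this carbonyl carbon now moves the number beyond the scatter, which the only earlier step, a 1.1-fold higher number from compound 1 to compound 2 (0.05 log units; within the scatter), did not show. Diisobutylamino gives a 2.3-fold lower number from compound 2 to compound 3 (0.36 log units; beyond the scatter) in place of hexylamino and a 2.1-fold lower number from compound 1 to compound 3 (0.32 log units; beyond the scatter) in place of 4-chloropiperidin-1-yl, so it stands apart from both earlier groups, though both steps are modest. No measurement here bears on why the number is lower with diisobutylamino.

Hexylamino carries a hydrogen-bond donor and diisobutylamino carries none, but the two groups also differ in their chains, and the compounds shown cannot separate these differences. From the compounds shown here alone, it also remains open whether a tertiary amide with straight chains, such as dibutylamino, or a morpholin-4-yl group on this carbon would give a similar number.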